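Bromo in place of carbamoyl on the shared core

A few compounds are considered here, and "the series" means these few. Any claim that something is new, unique, unknown or untested is made for them only; others in the source may bear on it.

Among the compounds with values here, compound 1 `COc1ccc(C(N)=O)cc1S(=O)(=O)Nc1cccnc1` carries a carbamoyl group on the shared core, and in an assay on isolated protein for inhibition of alkaline phosphatase, tissue-nonspecific isozyme (Homo sapiens) (a lower number here means a stronger inhibitor, a higher number a weaker inhibitor), compound 1 gives 1490 nM, the highest of the three numbers measured so far. Compound 2 `COc1ccc(Cl)cc1S(=O)(=O)Nc1cncc(C(=O)O)c1` gives 134 nM and compound 3 `COC(=O)c1cncc(NS(=O)(=O)c2cc(Cl)ccc2OC)c1` gives 65 nM. Both carry chloro where compound 1 carries carbamoyl, but both also carry an acid or its methyl ester on the other ring, so their gap to compound 1 cannot be split between the two changes. Within the data shown here, the only single-point step in the set, a 2.1-fold lower number from compound 2 to compound 3 (0.31 log units; beyond the scatter), concerns the ester and does not touch the change at hand.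

Compound 4 `COc1ccc(Br)cc1S(=O)(=O)Nc1cccnc1` differs from compound 1 by bromo in place of carbamoyl on an aromatic carbon. Among the measured compounds shown here, no measured step bears on this change directly. The lower numbers of compound 2 (134 nM) and of compound 3 (65 nM), each carrying a halogen where compound 1 carries carbamoyl, point toward a lower number, but the confounding with the other ring leaves the size open. A lower number than compound 1 is therefore expected in this assay, with a wide range. Compound 4 is expected to give about 350 nM, between 90 nM and 1400 nM, which means an expected step of a 4.3-fold lower number from compound 1 to compound 4 (0.63 log units; beyond the scatter).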

Compound 4, half-maximal inhibitory concentration: 43 nM
Beside the measured number, compound 4's estimate is 8.1-fold (0.91 log units) above it, and the stated range ends above it.
By their numbers in this assay, from the lowest: compounds 4 and 3 (each within the scatter of the next); then compound 2; then compound 1.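

In this assay, within the data shown here, bromo in place of carbamoyl on an aromatic carbon gives a 35-fold lower number from compound 1 to compound 4 (1.54 log units; beyond the scatter), a large step and the first reading of this change with the other ring held constant, which compounds 2 and 3 could not give. At this place, para to a methoxy group, the carbamoyl group with its hydrogen-bond donor and acceptor is thus not required for a low number in this pair: compound 4 carries a single bromine atom there, with neither. Nothing measured here accounts for the size of the step.

Going by these compounds, whether the step reflects the arrival of bromo or the departure of carbamoyl remains open, and a methyl group or a nitrile at this place, with the other ring as in compound 4, would help to separate the two. Also open, on these data alone, is what a carboxylic acid or its methyl ester on the other ring would do in a compound otherwise matching compound 4.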